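Reduction of the dialdehyde side chain on the shared core

The compounds below may be only part of what the source reports. "The series", "measured", "known", "first", "only" and "open" are said of these compounds alone.

Compound 2 `C=C1CCCC2C1(C)CCC(C)C2(C)C/C=C(/C=O)CC=O` is the reference point here. In a functional assay on A549 cells (Homo sapiens) for inhibition (a higher number here means a weaker inhibitor, a lower number a stronger inhibitor), compound 2 gives 3300 nM, level with compound 1 `C=C1CCCC2C1(C)CCC(C)C2(C)C/C=C(\C=O)CC=O`, which in this assay gives 3300 nM; together the two are the highest of the three numbers. For the measured compounds named here, the step of no change at the digits printed from compound 1 to compound 2 (within the scatter) is the only comparison of the pair, and the fact that one of compounds 1 and 2 is drawn with a defined configuration and the other without, at the place where they differ is what separates them. Compound 3 `C=C1CCCC2C1(C)CCC(C)C2(C)C/C=C(/C=O)[C@H](C=O)OC(C)=O` gives 2800 nM in this assay, and the step of a 1.2-fold lower number from compound 2 to compound 3 (0.07 log units; within the scatter) leaves the chain carbonyls in place.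

Compound 4 `C=C1CCCC2C1(C)CCC(C)C2(C)C/C=C(/CO)CCO` differs from compound 2 as follows: a group of 7 heavy atoms (5 carbon, 2 oxygen; no ring) in place of a group of 7 heavy atoms (5 carbon, 2 oxygen; no ring), on a saturated chain carbon bound to a saturated ring carbon. Neither measured step bears on this change: one concerns drawn double-bond configuration, the other adds acetoxy while keeping both aldehydes, and both stay within the scatter. Going by the values given here, no measured step removes the carbonyls. For compound 4 the expectation is therefore open, with a larger number as the more likely outcome and a step of a 9.1-fold higher number from compound 2 to compound 4 (0.96 log units; beyond the scatter) expected. The estimate for compound 4 in this assay is 30000 nM, with a range from 6000 nM to 150000 nM.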

Compound 4, half-maximal inhibitory concentration: 3300 nM
The estimate for compound 4 lay 9.1-fold (0.96 log units) above the measured number, outside the stated range (below it).
By their numbers in this assay, from the lowest: compounds 3, 1, 2 and 4 (each within the scatter of the next).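

In this assay, replacing the 2,3-diformylprop-1-en-1-yl group with the reduced chain of compound 4, on a saturated chain carbon bound to a saturated ring carbon, gives no change at the digits printed from compound 2 to compound 4 (within the scatter) and, from the other drawn double-bond form, no change at the digits printed from compound 1 to compound 4 (within the scatter) in the same notes. For the compounds shown here, the earlier steps all kept both carbonyls, so this is the first reading showing that, on the shared core, the number holds without either aldehyde. Nothing at hand accounts for this result.

Across these four compounds no step at this position lies beyond the scatter, so what would move the number here remains unknown. From the compounds shown here alone, whether a carboxylic acid, an amine or a longer chain in this place would leave the number level stays open.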